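A few compounds are considered here, and "the series" means these few. Any claim that something is new, unique, unknown or untested is made for them only; others in the source may bear on it.

In an ADME assay on SH-SY5Y cells (Homo sapiens) for cytotoxicity, read by MTT assay, with a stated time of 72 h (on this read-out higher numbers stand for weaker inhibition and lower numbers for stronger inhibition), compound 2 `O=C(CN1CCN(C(=O)c2ccc(Br)cc2)CC1)N1CCN(CCCc2c[nH]c3ccccc23)CC1` gives 59300 nM, the lowest of the three numbers measured, while compound 3 `O=C(CN1CCN(C(=O)c2cccc(Cl)c2)CC1)N1CCN(CCCc2c[nH]c3ccccc23)CC1` gives 120000 nM and compound 1 `COc1ccc(C(=O)N2CCN(CC(=O)N3CCN(CCCc4c[nH]c5ccccc45)CC3)CC2)cc1` gives 148000 nM. Compound 4 `COc1ccc2[nH]cc(CCCN3CCN(C(=O)CN4CCN(C(=O)c5ccc(Br)cc5)CC4)CC3)c2c1` differs from compound 2 by one change: methoxy in place of hydrogen on an aromatic carbon. The nearest evidence comes from elsewhere in the molecule, where bromo in place of methoxy gave a 2.5-fold lower number from compound 1 to compound 2 (0.40 log units; beyond the scatter), and 3-chlorophenyl in place of 4-methoxyphenyl gave a 1.2-fold lower number from compound 1 to compound 3 (0.09 log units; within the scatter). Neither step adds methoxy at this place, so only a small rise is expected in this assay. The estimated change is a 1.3-fold higher number from compound 2 to compound 4 (0.13 log units; within the scatter). For compound 4 the expected value is 80000 nM, with an estimated range from 35000 nM to 180000 nM.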

Compound 4, half-maximal inhibitory concentration: 150000 nM
Compound 4: middle estimate off by 1.9-fold (0.27 log units), on the low side; measured number inside the range.
By their numbers in this assay, from the lowest: compound 2; then compounds 3, 1 and 4 (each within the scatter of the next).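

In this assay, changing 1H-indol-3-yl to 5-methoxy-1H-indol-3-yl gives a 2.5-fold higher number from compound 2 to compound 4 (0.40 log units; beyond the scatter), so the number responds to a change on this ring as well as to changes on the aromatic ring at the other end of the molecule. The step is modest, but here a higher number means weaker inhibition, so adding methoxy at this place weakens the cytotoxic effect of compound 2. Nothing measured here explains this rise.

On these data alone, it remains open whether a fluoro or hydroxyl group on the same carbon would shift the number as methoxy does. Also open, as far as these compounds go, is whether the rise would recur with 3-chlorophenyl or 4-methoxyphenyl on the carbonyl carbon in place of 4-bromophenyl.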